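The source may report more compounds than this note shows. Statements on the series, on what has been measured and on what is new or still open speak of the compounds shown alone.

Working notes on the series. Compound 1 `Nc1ncc(-c2cnn(C3CCNCC3)c2)cc1-c1nc2ccc(Oc3ccccc3)cc2o1` gives 4000 nM in an assay on isolated protein for inhibition of G protein-coupled receptor kinase 5 (Homo sapiens), read by TR-FRET, with stated times of 10 min and 1 h; on this read-out higher numbers stand for weaker inhibition and lower numbers for stronger inhibition; compound 2 `Nc1ncc(-c2cnn(C3CCNCC3)c2)cc1-c1nc2ccc(NC(=O)Nc3ccccc3)cc2o1` gives 1660 nM in this assay. For the measured compounds named here, the only step so far, a 2.4-fold lower number from compound 1 to compound 2 (0.38 log units; beyond the scatter), leaves compound 2 with the lowest of the two numbers, with compound 1 the nearest. Compound 3 `COc1ccc(C(=O)Nc2ccc3nc(-c4cc(-c5cnn(C6CCNCC6)c5)cnc4N)oc3c2)cc1` has not yet been measured. Against compound 2 its change is 4-methoxyphenyl in place of anilino on a carbonyl carbon; the carbonyl and the attached amide-type nitrogen stay in place. Going by the values given here, no measured step bears directly on this change: the phenoxy-to-urea step shows that variation at this position shifts the number modestly, but gives no direction for the urea-to-amide exchange. Compound 3 is therefore expected near compound 2, with a 1.1-fold lower number from compound 2 to compound 3 (0.04 log units; within the scatter) judged as no step beyond the scatter. The estimate for compound 3 in this assay is 1500 nM, ranging from 500 nM to 5000 nM.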

Compound 3, half-maximal inhibitory concentration: 2090 nM
The estimate for compound 3 lay 1.4-fold (0.14 log units) below the measured number; the range from low to high includes it.
By their numbers in this assay, from the lowest: compounds 2, 3 and 1 (each within the scatter of the next, the first and the last beyond it).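

In this assay, the exchange on the carbonyl carbon gives a 1.3-fold higher number from compound 2 to compound 3 (0.10 log units; within the scatter), so losing the anilino hydrogen-bond donor and gaining the 4-methoxyphenyl acceptor does not shift the number beyond the scatter. Measured against phenoxy, ((4-methoxyphenyl)carbonyl)amino gives a 1.9-fold lower number from compound 1 to compound 3 (0.28 log units; within the scatter), which also stays within the scatter, whereas (phenylcarbamoyl)amino is the only one of the two replacements whose step from phenoxy is printed as beyond it. The three groups at this position therefore stay close together, and the hydrogen-bond donor of the anilino group is not shown to matter in the step from compound 2 to compound 3.

Still open, going by these compounds, is whether a primary amine or a carboxylic acid on the phenyl ring, or a longer chain at the carbonyl carbon, would move the number further. No measurement shown gives a reason for these results.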